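Fluorinated phenyl replacements on the ring nitrogen

The source may hold more compounds than are shown below. What is called first, only, known or untested is meant among the compounds shown, and "the series" means these compounds.

Compound 1 `Nc1scc(CN2CCN(c3ccc(Cl)cc3Cl)CC2)c1C(=O)c1ccc(Cl)cc1` carries a 2,4-dichlorophenyl on an amine nitrogen in a ring. In an assay on CHO cells for displacement of a labelled ligand from adenosine receptor A1 (Homo sapiens), read by scintillation counting, with a stated time of 120 min, tested at 10 uM (a higher number here means more inhibition at the concentration tested (going by the name of the read-out), a lower number less inhibition), compound 1 gives 0%. Compound 2 `Nc1scc(CN2CCN(c3cc(F)cc(F)c3)CC2)c1C(=O)c1ccc(Cl)cc1`, with a 3,5-difluorophenyl in that place, gives 0% in this assay, and compound 3 `Nc1scc(CN2CCN(c3c(F)cccc3F)CC2)c1C(=O)c1ccc(Cl)cc1`, with a 2,6-difluorophenyl, gives 1%. Compound 1 is level with compound 2 at the digits shown, and the two together sit at the low end of the three numbers; the furthest is compound 3, with a number 1 percentage points higher from compound 1 to compound 3 (within the scatter). The remaining steps are no change at the digits printed from compound 1 to compound 2 (within the scatter) and a number 1 percentage points higher from compound 2 to compound 3 (within the scatter); every step in the set lies within the scatter, so nothing here separates the three compounds.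

Compound 4 `Nc1scc(CN2CCN(c3c(F)cc(F)cc3F)CC2)c1C(=O)c1ccc(Cl)cc1` is not yet measured. Relative to compound 1 the change is 2,4,6-trifluorophenyl in place of 2,4-dichlorophenyl on an amine nitrogen in a ring. Going by the values given here, the steps that bear on it are those from compound 1 to compound 2 and from compound 1 to compound 3, both exchanging the same 2,4-dichlorophenyl for a fluorinated phenyl, and both flat within the scatter. The expected step is therefore a number 1 percentage points higher from compound 1 to compound 4 (within the scatter), none beyond the scatter. For compound 4 the estimate in this assay is 1%, with a range from -8% to 10%.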

Compound 4, a percentage reported as inhibition, at one concentration (the size of the read-out at that concentration, not a potency): 0%
For compound 4 the middle estimate is 1 percentage points above the measured one, and the stated range covers the measured number.
By their numbers in this assay, from the lowest: compounds 1, 2, 4 and 3 (each within the scatter of the next).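

Replacing the 2,4-dichlorophenyl on this amine nitrogen with 2,4,6-trifluorophenyl gives no change at the digits printed from compound 1 to compound 4 (within the scatter) in this assay, so a third fluorinated phenyl also fails to separate from the dichlorinated one. The series now also holds a step confined to one aromatic carbon, fluoro in place of hydrogen, which gives a number 1 percentage points lower from compound 3 to compound 4 (within the scatter), while the exchange from 3,5-difluorophenyl gives no change at the digits printed from compound 2 to compound 4 (within the scatter); at this position, neither this single added fluoro nor the different fluorine arrangements in these compounds separate the numbers. No supporting measurement is available to account for this result.

As far as these compounds go, all four compounds carry a halogenated phenyl on this nitrogen, so it remains open whether a different substituent, such as a methoxy group or a carboxylic acid on the phenyl, or a longer alkyl chain in place of the phenyl, would give a number beyond the scatter. With every step here within the scatter, these compounds also leave open whether this position has any influence on the read-out, and whether a change elsewhere on the shared core, such as at the 4-chlorobenzoyl group, would have more.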